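A few compounds are considered here, and "the series" means these few. Any claim that something is new, unique, unknown or untested is made for them only; others in the source may bear on it.

In an ADME assay on microsomes from liver (Mus musculus) for metabolic stability, read by LC-MS, using NADPH, with stated times of 10 min and 30 min, tested at 1 uM (on this read-out higher numbers stand for fast clearance and lower numbers for slow clearance), three compounds sharing one core and differing in the group on a saturated chain carbon bound to a double-bonded ring carbon have been measured. Compound 1 `COC(=O)C1=C(CN2CCCCC2)NC(c2nccs2)=NC1(C)c1ccc(F)cc1` gives 88 mL/min/kg, compound 2 `COC(=O)C1=C(CN2CCNC(=O)C2)NC(c2nccs2)=NC1(C)c1ccc(F)cc1` gives 81 mL/min/kg, and compound 3 `COC(=O)C1=C(CN2CCC(O)CC2)NC(c2nccs2)=NC1(C)c1ccc(F)cc1` gives 81 mL/min/kg. Compound 3 therefore stands level with compound 2 and within the scatter of compound 1.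

The next structure, compound 4 `COC(=O)C1=C(CN2CCCS2(=O)=O)NC(c2nccs2)=NC1(C)c1ccc(F)cc1`, changes that same place again: a group of 7 heavy atoms (3 carbon, 1 nitrogen, 2 oxygen, 1 sulfur; one five-membered non-aromatic ring with 2 hetero atoms) in place of a group of 7 heavy atoms (5 carbon, 1 nitrogen, 1 oxygen; one six-membered non-aromatic ring with 1 hetero atom), on a saturated chain carbon bound to a double-bonded ring carbon. Here 4-hydroxypiperidin-1-yl leaves, and a group with one five-membered non-aromatic ring with 2 hetero atoms enters.

Among the compounds with values here, three measured steps bear on this exchange: a 1.1-fold lower number from compound 1 to compound 2 (0.04 log units; within the scatter), a 1.1-fold lower number from compound 1 to compound 3 (0.04 log units; within the scatter) and no change at the digits printed from compound 2 to compound 3 (within the scatter). All three are small and lie within the scatter. Within the data shown here, none of the measured compounds carries a five-membered ring at this place, however, so the evidence reaches the new group only by analogy.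

Taking compound 3 at 81 mL/min/kg as the starting point, no step beyond the scatter is expected in this assay. The expected change is a 1.1-fold lower number from compound 3 to compound 4 (0.03 log units; within the scatter), with no firm direction. For compound 4 the estimated clearance is 75 mL/min/kg, with an expected range from 48 mL/min/kg to 100 mL/min/kg.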

Compound 4, clearance: 79 mL/min/kg
Beside the measured number, compound 4's estimate is 1.1-fold (0.02 log units) below it; low and high end bracket the measured number.
By their numbers in this assay, from the lowest: compounds 4, 2, 3 and 1 (each within the scatter of the next).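

The step of a 1.0-fold lower number from compound 3 to compound 4 (0.01 log units; within the scatter) shows that this place on a saturated chain carbon bound to a double-bonded ring carbon also accepts a five-membered non-aromatic ring with 2 hetero atoms, one of them sulfur, without leaving the scatter in this assay. The same holds against the two other six-membered rings, with a 1.0-fold lower number from compound 2 to compound 4 (0.01 log units; within the scatter) and a 1.1-fold lower number from compound 1 to compound 4 (0.05 log units; within the scatter), so that neither ring size nor the loss of the hydrogen-bond donor of 4-hydroxypiperidin-1-yl separates these four compounds on this read-out. No measurement is available that would account for this flat outcome.

All four groups shown are saturated rings bound through nitrogen, so it remains open whether a carboxylic acid, an open-chain amine or a longer chain at this place would give a step beyond the scatter in this assay. Going by these compounds, it also remains open whether a change elsewhere on the shared core, such as replacing the methyl ester or the 4-fluorophenyl group, would shift a clearance that stays high across all four compounds.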